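The source may hold more compounds than are shown below. What is called first, only, known or untested is meant among the compounds shown, and "the series" means these compounds.

Compound 1 `Oc1c(CN2CCCC2)cc(Cl)c2cccnc12` gives 7410 nM in a functional assay on A-431 cells (Homo sapiens) for inhibition, with a stated time of 72 h; on this read-out lower numbers stand for stronger inhibition and higher numbers for weaker inhibition
Compound 2 `Oc1c(CN2CCCC2)cc(Br)c2cccnc12` gives 4270 nM in this assay

Within the data shown here, compound 2 stands within the scatter of compound 1, the only other measured compound. Among the measured compounds shown here, the single measured step is a 1.7-fold lower number from compound 1 to compound 2 (0.24 log units; within the scatter) and it is all that bears on the next change. Compound 3 `CCOCc1cc(CN2CCCC2)c(O)c2ncccc12` has ethoxymethyl in place of bromo on an aromatic carbon and is unmeasured. For the measured compounds named here, no measured compound carries ethoxymethyl, so guidance is thin, and in this assay no step beyond the scatter is expected. The expected change is a 1.4-fold higher number from compound 2 to compound 3 (0.15 log units; within the scatter) and it remains an estimate. For compound 3 the estimated value is 6000 nM with an expected range from 2000 nM to 18000 nM here.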

Compound 3, half-maximal inhibitory concentration: 33100 nM
Estimate against measurement, compound 3: 5.5-fold (0.74 log units) below; the whole stated range lies below it.
By their numbers in this assay, from the lowest: compounds 2 and 1 (each within the scatter of the next); then compound 3.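

In this assay this position, para to a hydroxy group, gives its first step beyond the scatter: ethoxymethyl in place of bromo gives a 7.8-fold higher number from compound 2 to compound 3 (0.89 log units; beyond the scatter) and ethoxymethyl in place of chloro gives a 4.5-fold higher number from compound 1 to compound 3 (0.65 log units; beyond the scatter) on the same position. The exchange of one halogen for the other stays within the scatter, so only the move to ethoxymethyl separates these compounds. Nothing available bears on the cause of this rise.

On these data alone, whether the chain length or its ether oxygen goes with the weaker number remains open. A propyl chain and a methoxymethyl group would help separate the two.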